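The compounds below may be only part of what the source reports. "The series", "measured", "known", "first", "only" and "open" are said of these compounds alone.

Compound 1 `O=c1[nH]nc(NCc2ccccc2)cc1-c1ccccc1` carries a benzyl group on a ring nitrogen of its core. In an assay for inhibition of casein kinase I isoform alpha (Sus scrofa), read by scintillation counting and 33P incorporation, with a stated time of 30 min, in the presence of a further agent that is not named here (a lower number here means a stronger inhibitor, a higher number a weaker inhibitor), compound 1 gives > 10000 nM, which is a limit of the assay rather than a measured number. Compound 2 `CCCNc1n[nH]c(=O)cc1-c1ccccc1` shares the same core with a propyl group in place of the benzyl. In this assay compound 2 gives > 10000 nM, again a limit and not a number. Both values sit at the limit of > 10000 nM in this assay, at which 2 of the 2 values shown sit, so compound 1 cannot be ordered against compound 2, and all that is known of compound 1 is that its value is a limit.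

Compound 3 `CC(=O)Nc1cc(-c2ccccc2)c(=O)[nH]n1` arises from compound 1 through (acetyl in place of benzyl on a nitrogen on an aromatic ring). Within the data shown here, no measured pair of compounds shows a change of this kind, so its size in this assay cannot be read from the data. The step of a number no higher from compound 1 to compound 3 (the limit leaves the size open) is expected to stay within the usual scatter, with no clear direction. For compound 3 the expected value in this assay is 10000 nM, with a likely range from 3000 nM to 40000 nM, and a considerable chance that only a limit is reported again.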

Compound 3, half-maximal inhibitory concentration: > 10000 nM
Compound 3 ended at the assay's limit; the forecaster's own chance of this, stated with the estimate: 70%; the middle value sits exactly at the limit.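

No step can be read from compound 1 to compound 3, as each of the two carries only a limit of the assay: the limit of > 10000 nM in this assay, at which 3 of the 3 values shown sit.

The compounds shown leave open how strongly any of them acts in this assay and whether benzyl, propyl or acetyl on the shared core makes any difference to the value at all.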